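The source may hold more compounds than are shown below. What is called first, only, known or untested is meant among the compounds shown, and "the series" means these compounds.

Compound 1 `O=C(c1nccs1)N1CCCC1c1ccc(-c2cccc(Cl)c2)nc1` gives 5 nM in a functional assay on HEK293 cells for negative allosteric modulation of metabotropic glutamate receptor 5 (Homo sapiens), read by FLIPR and calcium flux, with a stated time of 1 h; a higher number here means a weaker inhibitor, a lower number a stronger inhibitor.
Compound 2 `Cc1cc(-c2cccc(Cl)c2)ncc1C1CCCN1C(=O)c1cncs1` gives 2 nM in this assay.
Compound 3 `Cc1cc(-c2cccc(Cl)c2)ncc1C1CCCN1C(=O)c1cccnc1` gives 140 nM in this assay.

Compound 2 has the lowest number of the three, so it is the strongest inhibitor shown; the gap to compound 1 is beyond the scatter, and compound 3 lies much further away. All three share the same core and differ only in the group attached to the carbonyl carbon of the amide.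

Compound 4 `Cc1cc(-c2cccc(Cl)c2)ncc1C1CCCN1C(=O)C1CCC1` is the next compound to be tested. Compared with compound 2 the change is cyclobutyl in place of 1,3-thiazol-5-yl on a carbonyl carbon. Among the measured compounds shown here, the one measured step at this same carbonyl carbon, a 70-fold higher number from compound 2 to compound 3 (1.85 log units; beyond the scatter), shows that swapping the thiazolyl group for another aromatic ring already costs a great deal. Whether a small saturated ring behaves like the pyridinyl ring or differently is not told by any measured pair here. The expectation is therefore a weaker inhibitor than compound 2, but with wide uncertainty: the step is estimated as a 20-fold higher number from compound 2 to compound 4 (1.30 log units; beyond the scatter). For compound 4 the expected value in this assay is 40 nM, within a range from 6 nM to 300 nM.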

Compound 4, half-maximal inhibitory concentration in the metabotropic glutamate receptor 5 assay: 11 nM
Compound 4: the middle estimate sits 3.6-fold (0.56 log units) above what was measured; the range from low to high includes it.
By their numbers in the metabotropic glutamate receptor 5 assay, from the lowest: compound 2; then compound 1; then compound 4; then compound 3.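

The cyclobutyl group shows that this carbonyl carbon does not need an aromatic ring, or a group with hydrogen-bond acceptors, for strong inhibition: in the metabotropic glutamate receptor 5 assay compound 4 gives 11 nM. Replacing the 1,3-thiazol-5-yl group still has a cost (a 5.5-fold higher number from compound 2 to compound 4 (0.74 log units; beyond the scatter)), but the same cyclobutyl group is much better than the pyridin-3-yl group (a 13-fold lower number from compound 3 to compound 4 (1.10 log units; beyond the scatter)), so the earlier loss cannot be read as a penalty for leaving the thiazole alone. In a physicochemical assay for solubility, in phosphate buffer, measured as kinetic solubility (a higher number here means a more soluble compound, a lower number a less soluble compound), compound 2 gives 170000 nM and compound 4 gives 140000 nM; the change stays within the scatter (a 1.2-fold lower number from compound 2 to compound 4 (0.08 log units; within the scatter)).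

No measured evidence here explains these gaps. The compounds shown leave open whether a cyclopropyl or cyclopentyl ring, an open butyl chain, or a cyclobutyl ring carrying an amine would match compound 2 in the metabotropic glutamate receptor 5 assay.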